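The source may report more compounds than this note shows. Statements on the series, on what has been measured and on what is new or still open speak of the compounds shown alone.

Compound 1 `CCC1(CCCCN2CCN(c3cccc(Cl)c3)CC2)C(=O)Nc2cc(F)ccc21` is the reference point in an assay on CHO cells for displacement of a labelled ligand from 5-hydroxytryptamine receptor 7 (Homo sapiens) (a higher number here means a weaker inhibitor, a lower number a stronger inhibitor), where compound 1 gives 0.67 nM. Two related compounds have been measured beside it. Compound 3 `CC(C)CC1(CCCCN2CCN(c3cccc(Cl)c3)CC2)C(=O)Nc2ccccc21` carries a longer branched chain on the shared core and gives 1.8 nM in this assay. Compound 2 `CCC1(CCCCN2CCN(c3cccc(Cl)c3)CC2)C(=O)Nc2c(Cl)cc(Cl)cc21` bears two chloro groups on the fused ring and gives 9.46 nM. Of the three numbers, compound 1 has the lowest and is the strongest inhibitor here; its gaps to compound 3 and to compound 2 both lie beyond the usual scatter of repeated measurements.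

Compound 4 `CCC1(CCCCN2CCN(c3cccc(Cl)c3)CC2)C(=O)Nc2cc(F)c(Cl)cc21` has not yet been measured. It differs from compound 1 in one place: chloro in place of hydrogen on an aromatic carbon. The new chloro sits ortho to a fluoro group on the fused ring of the core. Among the compounds with values here, no measured pair isolates this exact change, so its size can only be judged from the surrounding numbers. Within the data shown here, an upward move is expected because compound 2, the only other compound with chloro on that ring, gives 9.46 nM, well above compound 1. The step from compound 1 to compound 4 is estimated at a 3.0-fold higher number from compound 1 to compound 4 (0.47 log units; beyond the scatter), beyond the scatter but short of the gap that compound 2 shows. Compound 4 is thus expected to give about 2 nM in this assay, with a likely range from 0.8 nM to 6 nM.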

Compound 4, inhibition constant: 9.07 nM
Beside the measured number, compound 4's estimate is 4.5-fold (0.66 log units) below it, outside the stated range (above it).
By their numbers in this assay, from the lowest: compound 1; then compound 3; then compounds 4 and 2 (each within the scatter of the next).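

Putting chloro in place of hydrogen on this aromatic carbon, ortho to a fluoro group on the shared core, gives a 14-fold higher number from compound 1 to compound 4 (1.13 log units; beyond the scatter) in this assay. Within the data shown here, this is the first step that changes only one place, since the earlier compounds all differ from one another in more than one place and could not single out any position. It shows that one added heavy atom on this carbon is enough to make a much weaker inhibitor, so the number responds strongly to this change, and no measurement at hand explains why.

From the compounds shown here alone, whether this large step belongs to chloro itself or to any group on this carbon stays open, and methyl, methoxy or an amine at the same place would help to separate the two. Also open, going by these compounds, is whether the fluoro group matters to the size of the step, which a compound with chloro on this carbon and hydrogen in place of the fluoro would show.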